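A few compounds are considered here, and "the series" means these few. Any claim that something is new, unique, unknown or untested is made for them only; others in the source may bear on it.

Measured compounds in a functional assay on DU-145 cells (Homo sapiens) for inhibition, read by MTT assay, with a stated time of 24 h; a lower number here means a stronger inhibitor, a higher number a weaker inhibitor:

- compound 1 `CCOC(=O)C1=Cc2ccccc2OC1(OCc1cc(-c2ccc(Br)cc2)no1)C(F)(F)F` gives 71700 nM
- compound 2 `CCOC(=O)C1=Cc2ccccc2OC1(OCc1cn(-c2ccccc2)nn1)C(F)(F)F` reaches only a limit of the assay, > 150000 nM
- compound 3 `CCOC(=O)C1=Cc2ccccc2OC1(OCc1cc(-c2ccc(C)cc2)no1)C(F)(F)F` reaches only a limit of the assay, > 150000 nM

Compound 2 therefore stands at the edge of what this assay can report: its value is a limit, not a number, and it shares this position with one other compound, as the limit of > 150000 nM in this assay, at which 2 of the 3 values shown sit, shows. Compound 1 is the only one of the three with a measured number.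

Compound 4 `CCOC(=O)C1=Cc2ccccc2OC1(OCc1cn(-c2ccc([N+](=O)[O-])cc2)nn1)C(F)(F)F` differs from compound 2 in one place: nitro in place of hydrogen on an aromatic carbon.

Within the data shown here, the only measured step, an at least 2.0-fold higher number from compound 1 to compound 3 (0.32 log units; beyond the scatter), concerns a different exchange on a different part of the shared core, so it does not speak directly to the change from compound 2 to compound 4. Among the measured compounds shown here, no measured pair shows what a nitro group does in this assay, and compound 2 itself offers only a limit as a starting point.

With nothing beyond the scatter to point either way, the expectation for compound 4 is a step of about an at least 1.2-fold lower number from compound 2 to compound 4 (0.09 log units; that floor lies within the scatter), most likely again ending at or near the limit. The estimated value for compound 4 is 120000 nM, with a range from 30000 nM to 400000 nM.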

Compound 4, half-maximal inhibitory concentration: > 150000 nM
Compound 4: no number, only a limit; the forecaster's own chance of this, stated with the estimate: 60%; middle value at least 1.2-fold (0.09 log units) from the limit.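

In this assay compound 4 gives only a limit of the assay, > 150000 nM. Compound 2 also gives only a limit, so no step can be read between compound 2 and compound 4, and the comparison stays without a size: the limit of > 150000 nM in this assay, at which 3 of the 4 values shown sit.

The compounds shown leave open whether going from phenyl to 4-nitrophenyl changes inhibition at all.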